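Methyl replacing cyclopropyl on the piperazine nitrogen

This account rests on a few compounds, and the source may have more. Where it says the series, first, only, none or still open, it means among the compounds named here.

Of the compounds shown here, two have been measured in a functional assay on CCRF-CEM cells for antagonist activity at C-X-C chemokine receptor type 4 (Homo sapiens), read by calcium flux, with stated times of 25 min and 90 s; on this read-out higher numbers stand for weaker inhibition and lower numbers for stronger inhibition. Compound 1 `CCN1CCN(CCCN(C[C@H]2Cc3ccccc3CN2)[C@H]2CCCc3cccnc32)CC1` gives 33 nM in this assay. Compound 2 `c1ccc2c(c1)CN[C@@H](CN(CCCN1CCN(C3CC3)CC1)[C@H]1CCCc3cccnc31)C2` gives 50 nM in this assay. The only difference between them is cyclopropyl in place of ethyl on an amine nitrogen in a ring, and that change brought a 1.5-fold higher number from compound 1 to compound 2 (0.18 log units; within the scatter), so the two numbers cannot be told apart by this assay. Compound 2 therefore stands beside compound 1 rather than apart from it.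

Compound 3 `CN1CCN(CCCN(C[C@H]2Cc3ccccc3CN2)[C@H]2CCCc3cccnc32)CC1` is not yet measured. It differs from compound 2 by methyl in place of cyclopropyl on an amine nitrogen in a ring. Going by the values given here, the one measured step that bears on this position is a 1.5-fold higher number from compound 1 to compound 2 (0.18 log units; within the scatter), and it was small. Moving from cyclopropyl to methyl is of the same kind, so the expected step is a 1.4-fold lower number from compound 2 to compound 3 (0.15 log units; within the scatter), that is, no change beyond the scatter in either direction. Compound 3 is accordingly estimated at 35 nM in this assay, with a likely range from 15 nM to 90 nM.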

Compound 3, half-maximal inhibitory concentration: 125 nM
For compound 3 the middle estimate is 3.6-fold (0.55 log units) below the measured one; the measured number lies above the stated range.
By their numbers in this assay, from the lowest: compounds 1 and 2 (each within the scatter of the next); then compound 3.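

In this assay, this position proves sensitive to its substituent after all: methyl replacing cyclopropyl gives a 2.5-fold higher number from compound 2 to compound 3 (0.40 log units; beyond the scatter), and methyl replacing ethyl gives a 3.8-fold higher number from compound 1 to compound 3 (0.58 log units; beyond the scatter). The earlier step between ethyl and cyclopropyl lay within the scatter and suggested a tolerant position, but that holds only for these two groups, and the weaker inhibition appears with the one-carbon methyl group, a pattern that none of the three compounds goes against. Nothing available here accounts for this difference.

The compounds shown leave open whether a piperazine nitrogen bearing only hydrogen would weaken inhibition further, and whether isopropyl, cyclobutyl or a longer chain such as n-propyl would stay level with ethyl and cyclopropyl or go beyond them. Going by these compounds, it also remains open whether a group of another kind on this nitrogen, such as acetyl or 2-hydroxyethyl, would follow the same pattern as the simple carbon groups.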